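The source may hold more compounds than are shown below. What is called first, only, known or untested is meant among the compounds shown, and "the series" means these compounds.

Compound 1 `NC(=O)c1c(NC(=O)c2ccccc2Cl)sc2c1CCN(Cc1ccc(Cl)cc1Cl)C2` is one of three analogues that share a core and differ only in the acyl group on the amide nitrogen. In a functional assay on MKN-74 cells (Homo sapiens) for antiproliferative activity, with a stated time of 24 h (on this read-out lower numbers stand for stronger inhibition and higher numbers for weaker inhibition), compound 1 gives 16300 nM, which is the second highest of the three numbers. Compound 2 `NC(=O)c1c(NC(=O)c2ccc(C(F)(F)F)cc2)sc2c1CCN(Cc1ccc(Cl)cc1Cl)C2` gives 10900 nM in this assay, and compound 3 `Cc1ccc(C(=O)Nc2sc3c(c2C(N)=O)CCN(Cc2ccc(Cl)cc2Cl)C3)cc1` gives 25500 nM. The steps among them are small: a 1.5-fold lower number from compound 1 to compound 2 (0.17 log units; within the scatter), a 1.6-fold higher number from compound 1 to compound 3 (0.19 log units; within the scatter), and a 2.3-fold higher number from compound 2 to compound 3 (0.37 log units; beyond the scatter). All three compounds therefore sit in a narrow band of weak activity.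

Compound 4 `NC(=O)c1c(NC(=O)c2ccccc2Cl)sc2c1CCN(C(=S)Nc1cccnc1)C2` departs from compound 1 at a different site. The change is a group of 9 heavy atoms (6 carbon, 2 nitrogen, 1 sulfur; one six-membered aromatic ring with 1 hetero atom) in place of a group of 9 heavy atoms (7 carbon, 2 chlorine; one six-membered aromatic ring of carbon only), on an amine nitrogen in a ring. Among the measured compounds shown here, none of the measured steps bears on this position; each of them alters the group on the carbonyl carbon while the 2,4-dichlorobenzyl on the amine nitrogen in the ring stays fixed. For the measured compounds named here, there is thus no measured step to anchor the direction or size of the effect, and the weak activity of compound 1 at 16300 nM is the only reference point. Compound 4 is expected to stay near that number, with a 1.0-fold lower number from compound 1 to compound 4 (0.01 log units; within the scatter) as the expected step, and its estimated value in this assay is 16000 nM, within a range of 4000 nM to 60000 nM.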

Compound 4, half-maximal inhibitory concentration: 38600 nM
Estimate against measurement, compound 4: 2.4-fold (0.38 log units) below, and the stated range covers the measured number.
By their numbers in this assay, from the lowest: compounds 2, 1, 3 and 4 (each within the scatter of the next, the first and the last beyond it).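

Among the compounds shown here, with the 2,4-dichlorobenzyl on the amine nitrogen in the ring replaced, this assay gives a 2.4-fold higher number from compound 1 to compound 4 (0.37 log units; beyond the scatter), so this position, which stayed fixed in the earlier compounds, does affect the read-out, and the only change measured here goes towards weaker inhibition. The step is modest and matches in size the largest step seen among the groups on the carbonyl carbon, a 2.3-fold higher number from compound 2 to compound 3 (0.37 log units; beyond the scatter), even though the entering group has the same count of 9 heavy atoms as the one it replaces and differs in having a six-membered aromatic ring with 1 hetero atom, 1 double bond outside aromatic rings, 1 hydrogen-bond donor and 2 hydrogen-bond acceptors. No measurement here shows which of these differences accounts for the step.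

Going by these compounds, with a single replacement at this position, paired with a single group on the carbonyl carbon, it remains open whether the step would hold alongside the 4-(trifluoromethyl)phenyl of compound 2. On these data alone, it is also open how a plain benzyl, a methyl or a carboxylic acid-bearing chain on the amine nitrogen in the ring would read in this assay.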